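Working notes: 3-chlorobenzyl to 2-fluorobenzyl in the series

The source may hold more compounds than are shown below. What is called first, only, known or untested is meant among the compounds shown, and "the series" means these compounds.

Of the compounds shown here, two sharing one core have been measured so far. In a functional assay on 4T1 cells (Mus musculus) for cytotoxicity, read by MTT assay, with a stated time of 24 h (a higher number here means a weaker inhibitor, a lower number a stronger inhibitor), compound 1 (`Cc1ccc(/C=C2\CN(Cc3cn(Cc4ccc(F)cc4)nn3)C/C(=C\c3ccc(C)cc3)C2=O)cc1`) gives 57200 nM. In this assay, compound 2 (`Cc1ccc(/C=C2\CN(Cc3cn(Cc4cccc(Cl)c4)nn3)C/C(=C\c3ccc(C)cc3)C2=O)cc1`) gives 29300 nM. On these numbers compound 2 cannot be separated from compound 1, the only other measured point.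

The next compound is compound 3 (`Cc1ccc(/C=C2\CN(Cc3cn(Cc4ccccc4F)nn3)C/C(=C\c3ccc(C)cc3)C2=O)cc1`), with 2-fluorophenyl in place of 3-chlorophenyl on a saturated chain carbon bound to an aromatic nitrogen. The same difference, cut one bond further out, reads 3-chlorobenzyl to 2-fluorobenzyl.

Among the compounds with values here, only one measured step bears on this exchange, since it falls at the same place: a 2.0-fold lower number from compound 1 to compound 2 (0.29 log units; within the scatter). That step stays within the scatter. Within the data shown here, no measured compound yet carries the 2-fluorophenyl group, so the expectation rests on this single step. The expected step is a 1.4-fold higher number from compound 2 to compound 3 (0.14 log units; within the scatter), which means no change beyond the scatter in this assay. For compound 3 the estimate is 40000 nM, with an expected range of 17000 nM to 85000 nM.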

Compound 3, half-maximal inhibitory concentration: 18000 nM
Compound 3: the middle estimate sits 2.2-fold (0.35 log units) above what was measured, and the stated range covers the measured number.
By their numbers in this assay, from the lowest: compounds 3, 2 and 1 (each within the scatter of the next, the first and the last beyond it).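

In this assay, 2-fluorophenyl in place of 3-chlorophenyl on a saturated chain carbon bound to an aromatic nitrogen gives a 1.6-fold lower number from compound 2 to compound 3 (0.21 log units; within the scatter), so compound 3 cannot be separated from compound 2, just as compound 2 could not be separated from compound 1. The new finding comes from the other pair: 2-fluorophenyl in place of 4-fluorophenyl gives a 3.2-fold lower number from compound 1 to compound 3 (0.50 log units; beyond the scatter), a modest step but the first in the series to pass beyond the scatter, which shows that this place can register a change even when fluorine is present in both groups and the shared core stays the same. No measurement available here accounts for either step.

All three groups at this place are halogen-bearing phenyl rings, so the compounds shown leave open how an unsubstituted phenyl, a methoxyphenyl or a phenyl carrying a carboxylic acid would read in this assay. They also leave open whether the separation of compound 3 from compound 1 would hold with a chlorine in place of fluorine on the same ring, as the 2-chlorophenyl and 4-chlorophenyl groups are not among them.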